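The compounds below may be only part of what the source reports. "The series", "measured", "known", "first", "only" and "open" are said of these compounds alone.

The measured compounds:
compound 1, `COc1ccc(-c2cc(/C=C/C(=O)c3ccc(OC)c(OC)c3)[nH]n2)cc1`, 17100 nM;
compound 2, `COc1cc(-c2cc(/C=C/C(=O)c3ccc(Cl)c(Cl)c3)[nH]n2)cc(OC)c1OC`, 18800 nM;
compound 3, `COc1cc(C(=O)/C=C/c2cc(-c3cc(OC)c(OC)c(OC)c3)n[nH]2)cc(OC)c1OC`, 11100 nM.

All three were tested in a functional assay on SK-OV-3 cells (Homo sapiens) for inhibition, read by sulforhodamine B assay, with a stated time of 48 h; on this read-out lower numbers stand for stronger inhibition of growth and higher numbers for weaker inhibition of growth. Compound 2 has the highest number of the three, but its gap to compound 1 and its gap to compound 3 both lie within the scatter, so no order among the three can be read from these numbers. Compound 4, `COc1cc(-c2cc(/C=C/C(=O)c3ccc(F)c(F)c3)[nH]n2)cc(OC)c1OC`, has not yet been measured. It differs from compound 2 in one place: 3,4-difluorophenyl in place of 3,4-dichlorophenyl on a carbonyl carbon. Among the measured compounds shown here, no pair of measured compounds differing in a single place is available, so the size of such a step cannot be read from the data. The three values sit close together, and nothing among them points to a change beyond the scatter. The step from compound 2 to compound 4 is expected to be a 1.1-fold higher number from compound 2 to compound 4 (0.03 log units; within the scatter), that is, nothing beyond the scatter. Compound 4 is therefore estimated at 20000 nM in this assay, within a range from 8000 nM to 50000 nM.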

Compound 4, concentration for total growth inhibition: 58600 nM
Compound 4: middle estimate off by 2.9-fold (0.47 log units), on the low side; the whole stated range lies below it.
By their numbers in this assay, from the lowest: compounds 3, 1 and 2 (each within the scatter of the next); then compound 4.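

In this assay, among the compounds shown here, the exchange of 3,4-dichlorophenyl for 3,4-difluorophenyl on a carbonyl carbon gives a 3.1-fold higher number from compound 2 to compound 4 (0.49 log units; beyond the scatter) and is the first step here that changes a single place, one that lies beyond the scatter. For the compounds shown here, it shows that this position is not indifferent to which of these two halogens the phenyl ring carries, something the earlier compounds, with no pair differing in one place, could not show. Nothing at hand explains the size or direction of this step.

The compounds shown leave open how a 3,4-dibromophenyl or an unsubstituted phenyl would stand at this position relative to these two groups. Going by these compounds alone, with only one pair available, they also leave open whether the same exchange would give a similar step on the core of compound 1.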